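The source may hold more compounds than are shown below. What is called first, only, known or untested is meant among the compounds shown, and "the series" means these compounds.

Measured in a functional assay on MC-38 cells (Mus musculus) for antiproliferative activity; on this read-out lower numbers stand for stronger inhibition and higher numbers for weaker inhibition
compound 1 `CS(=O)(=O)Nc1ccc(S(=O)(=O)Nc2cccc3c(C#N)c[nH]c23)cc1` gives 1.2 ug/mL
compound 2 `N#Cc1ccc(S(=O)(=O)Nc2cccc3c(Cl)c[nH]c23)cc1` gives 0.13 ug/mL
compound 3 `NC(=O)c1ccc(S(=O)(=O)Nc2cccc3c(Cl)c[nH]c23)cc1` gives 0.19 ug/mL

Compound 3 stands within the scatter of compound 2, and compound 1 shows a clearly higher number than both. Next comes compound 4 `CS(=O)(=O)Nc1ccc(S(=O)(=O)Nc2cccc3c(Cl)c[nH]c23)cc1` with methanesulfonamido in place of carbamoyl on an aromatic carbon at the same place, para to a large group. Among the compounds with values here, the one measured step at that place is a 1.5-fold higher number from compound 2 to compound 3 (0.16 log units; within the scatter) and it stays within the scatter. Compound 1 also carries methanesulfonamido, on a different core, and its 1.2 ug/mL argues for caution, so a slightly higher number is expected. The estimated step is a 1.6-fold higher number from compound 3 to compound 4 (0.20 log units; within the scatter) in this assay and it stays within the scatter. For compound 4 the expected value is 0.3 ug/mL with an estimated range from 0.1 ug/mL to 0.9 ug/mL in this series.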

Compound 4, half-maximal inhibitory concentration: 0.26 ug/mL
For compound 4 the middle estimate is 1.2-fold (0.06 log units) above the measured one; low and high end bracket the measured number.
By their numbers in this assay, from the lowest: compounds 2, 3 and 4 (each within the scatter of the next); then compound 1.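

In this assay, methanesulfonamido on the aromatic carbon para to a large group reads the same as carbamoyl, with a 1.4-fold higher number from compound 3 to compound 4 (0.14 log units; within the scatter), and the same as cyano, with a 2.0-fold higher number from compound 2 to compound 4 (0.30 log units; within the scatter). With methanesulfonamido held fixed, chloro in place of cyano on the core gives a 4.6-fold lower number from compound 1 to compound 4 (0.66 log units; beyond the scatter). No measurement at hand accounts for these steps. On these data alone, whether an amine or a carboxylic acid at the same place would also stay within the scatter remains open. So does whether a bromo or a methyl in place of chloro on the core would hold the number of compound 4.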